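A Cyclopropane Acid Weighed Against an Unreadable Limit

The compounds below may be only part of what the source reports. "The series", "measured", "known", "first", "only" and "open" are said of these compounds alone.

Compound 1 `O=C(O)c1ccc(NCc2cccc(Oc3ccccc3)c2)cc1` carries a plain carboxy group on its aromatic ring. In a functional assay on CHO cells for agonist activity at Free fatty acid receptor 1 (Homo sapiens) (on this read-out lower numbers stand for an effect already at smaller amounts and higher numbers for an effect only at larger amounts of compound), compound 1 gives only a limit of the assay, < 10000 nM. Compound 2 `Cc1nc(-c2ccc(C(F)(F)F)cc2)sc1CNc1ccc(C(=O)O)cc1` likewise returns only a limit in this assay, < 10000 nM. Compound 3 `Cc1nc(-c2ccc(C(F)(F)F)cc2)sc1CNc1ccc(/C=C/C(=O)O)cc1` gives a measured value in this assay of 36.3 nM. The step that the limit leaves unreadable from compound 2 to compound 3 cannot be sized because the limit of < 10000 nM in this assay, at which 2 of the 3 values shown sit, hides where the starting compound actually stands. Compound 4 `O=C(O)[C@@H]1C[C@H]1c1ccc(NCc2cccc(Oc3ccccc3)c2)cc1` differs from compound 1 by 2-carboxycyclopropyl in place of carboxy on an aromatic carbon. Going by the values given here, the only measured step that bears on this change is the one from carboxy to 2-carboxyethenyl, and its size is not readable. What the numbers do show is that compound 3, with its acid held away from the ring, reaches a well-defined value, so an extended acid is at least compatible with measurable activity in this assay. For compound 4 the expected value in this assay is 150 nM, within a range from 20 nM to 1500 nM. The step expected is a step that the limit leaves unreadable from compound 1 to compound 4, its direction unresolved since compound 1 has only a limit.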

Compound 4, half-maximal effective concentration: 562 nM
Estimate against measurement, compound 4: 3.7-fold (0.57 log units) below; the range from low to high includes it.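

No new step can be read between compound 1 and compound 4, because the comparison rests on a limit: the limit of < 10000 nM in this assay, at which 2 of the 4 values shown sit. The compounds shown leave open how large the effect of 2-carboxycyclopropyl in place of carboxy is, and in which direction it runs.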